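This account rests on a few compounds, and the source may have more. Where it says the series, first, only, none or still open, it means among the compounds named here.

Among the compounds with values here, compound 1 `CCCCCCCCCCCCCCCCCCNC(=O)[C@H]1CSC(Cc2ccccc2)N1` gives 16400 nM in a functional assay on PC-3 cells (Homo sapiens) for antiproliferative activity, read by sulforhodamine B assay (a higher number here means a weaker inhibitor, a lower number a stronger inhibitor), the highest of the two numbers measured so far. Compound 2 `CCCCCCCCCCCCCCCCCCNC(=O)[C@H]1CSC(c2cccnc2)N1` gives 9200 nM, and the step of a 1.8-fold lower number from compound 1 to compound 2 (0.25 log units; within the scatter) lies within the scatter. Compound 3 `CCCCCCCCCCCCCCCCCCNC(=O)[C@H]1CSC(c2c(Cl)cccc2Cl)N1` carries a change at the same place: 2,6-dichlorophenyl in place of benzyl on a saturated ring carbon. Within the data shown here, the only measured step that bears on it, a 1.8-fold lower number from compound 1 to compound 2 (0.25 log units; within the scatter), also exchanged the group on that saturated ring carbon and stayed within the scatter, so no step beyond the scatter is expected in a 1.4-fold lower number from compound 1 to compound 3 (0.14 log units; within the scatter). Compound 3 is therefore estimated at 12000 nM, with a range from 4500 nM to 32000 nM.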

Compound 3, half-maximal inhibitory concentration: > 20000 nM
Compound 3 ended at the assay's limit; the forecaster's own chance of this, stated with the estimate: 5%; middle value at least 1.6-fold (0.22 log units) away from the limit.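

Within the data shown here, the saturated ring carbon next to the ring nitrogen does respond to its group: 2,6-dichlorophenyl in place of pyridin-3-yl gives an at least 2.1-fold higher number from compound 2 to compound 3 (0.33 log units; beyond the scatter), the only step at this position beyond the scatter. In place of benzyl, the same group gives an at least 1.2-fold higher number from compound 1 to compound 3 (0.08 log units; that floor lies within the scatter), so that comparison remains unresolved. Compound 3 reads in this assay only as a limit, not as a number: the limit of > 20000 nM in this assay, at which 1 of the 3 values shown sits.

The compounds shown leave open how far compound 3 lies past its limit. They also leave open whether an unsubstituted phenyl or an aminophenyl at this carbon would give a lower number than compound 2.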